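A Longer Amine-Bearing Side Chain on the Shared Core

A few compounds are considered here, and "the series" means these few. Any claim that something is new, unique, unknown or untested is made for them only; others in the source may bear on it.

Three compounds share one core and differ only in the chain attached through an oxygen on an aromatic ring. Compound 1 `CCCCOc1c(-c2cc(OC)c(OC)c(OC)c2)oc2ccccc2c1=O` is the simplest of them; in a functional assay on LNCaP cells (Homo sapiens) for antiproliferative activity, read by WST assay, with a stated time of 3 days (on this read-out lower numbers stand for stronger inhibition and higher numbers for weaker inhibition), compound 1 gives 8900 nM, the lowest number among the three measured compounds. Compound 2 `CCCCCCOc1c(-c2cc(OC)c(OC)c(OC)c2)oc2ccccc2c1=O` gives 19600 nM, and compound 3 `CCN(CC)CCCCCOc1c(-c2cc(OC)c(OC)c(OC)c2)oc2ccccc2c1=O` gives 10000 nM.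

Compound 4 `CCCN(CCC)CCCCCOc1c(-c2cc(OC)c(OC)c(OC)c2)oc2ccccc2c1=O` has not yet been measured. It differs from compound 1 by (dipropylamino)methyl in place of hydrogen on a saturated chain carbon, four bonds along the chain from an oxygen on an aromatic ring. Among the measured compounds shown here, two measured steps bear on this change. Extending the chain with a plain ethyl gave a 2.2-fold higher number from compound 1 to compound 2 (0.34 log units; beyond the scatter), whereas attaching (diethylamino)methyl gave a 1.1-fold higher number from compound 1 to compound 3 (0.05 log units; within the scatter). The closest comparison is compound 3, whose chain ends in diethylamino where compound 4 ends in dipropylamino. The comparison of compound 2 with compound 3, a 2.0-fold lower number from compound 2 to compound 3 (0.29 log units; within the scatter), shows that the amine-ended chain sits close to compound 1 rather than following the plain chain. The step from compound 1 to compound 4 is therefore expected to be small, a 1.3-fold higher number from compound 1 to compound 4 (0.13 log units; within the scatter), with at most a slight drift toward a higher number. Compound 4 is estimated at 12000 nM, with a range from 5000 nM to 30000 nM.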

Compound 4, half-maximal inhibitory concentration: 7600 nM
Compound 4: middle estimate off by 1.6-fold (0.20 log units), on the high side; measured number inside the range.
By their numbers in this assay, from the lowest: compounds 4, 1, 3 and 2 (each within the scatter of the next, the first and the last beyond it).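

In this assay, dipropylamino in place of diethylamino at the end of the chain gives a 1.3-fold lower number from compound 3 to compound 4 (0.12 log units; within the scatter), so the two amines cannot be told apart at this position. The whole change, a (dipropylamino)methyl group of 8 heavy atoms in place of a hydrogen, also gives only a 1.2-fold lower number from compound 1 to compound 4 (0.07 log units; within the scatter), which means that this much larger amine-ended chain still cannot be separated from the simple chain of compound 1. Against the plain chain of compound 2, the earlier amine gave a 2.0-fold lower number from compound 2 to compound 3 (0.29 log units; within the scatter), whereas dipropylamino gives a 2.6-fold lower number from compound 2 to compound 4 (0.41 log units; beyond the scatter), so the gap between a plain chain and an amine-ended chain of this length now lies clearly beyond the scatter, though the step is modest.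

As far as these compounds go, it remains open whether a ring amine such as piperidine or morpholine, a carboxylic acid at the chain end, or a shorter chain carrying the same dipropylamino group would also stay level with compound 1. No measured evidence accompanies these numbers to account for the difference between the plain chain and the amine-ended chains.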